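Amide in place of sulfonyl on a shared core

The source may report more compounds than this note shows. Statements on the series, on what has been measured and on what is new or still open speak of the compounds shown alone.

Measured so far:
compound 1, `CC(C)=CCC1Cc2c(OCCCNS(=O)(=O)c3ccc(Br)cc3)cc(=O)n(CCCO)c2CC1(C)C`, 3.7%
compound 2, `CC(C)=CCC1Cc2c(OCCCNS(=O)(=O)c3ccc([N+](=O)[O-])cc3)cc(=O)n(CCCO)c2CC1(C)C`, 17.3%

Compound 1 and compound 2 were tested in a functional assay on PANC-1 cells (Homo sapiens) for inhibition, read by MTT assay, with a stated time of 24 h, tested at 10 uM; a lower number here means less inhibition, a higher number more inhibition at the concentration tested (going by the name of the read-out). Among the measured compounds shown here, compound 2 holds the higher of the two numbers; in this assay compound 2 gives 17.3%, and the only step measured, a number 13.6 percentage points higher from compound 1 to compound 2 (beyond the scatter), separates it from compound 1.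

Compound 3, `COc1ccc(C(=O)NCCCOc2cc(=O)n(CCCO)c3c2CC(CC=C(C)C)C(C)(C)C3)cc1`, has not yet been measured. It differs from compound 2 in one place: (4-methoxyphenyl)carbonyl in place of (4-nitrophenyl)sulfonyl on an amine nitrogen. For the measured compounds named here, no measured step touches this position in the same way. The step from compound 1 to compound 2 concerns only the group on the aromatic ring and leaves the sulfonyl part untouched, so it bears on compound 3 only indirectly, showing that changes at this end of the molecule have moved the number by a modest amount.

With so little to go on, the estimate for compound 3 leans toward a small decrease, a number 7.3 percentage points lower from compound 2 to compound 3 (within the scatter), and is expected to land near 10%, within a range from 0% to 30%.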

Compound 3, a percentage reported as inhibition, at one concentration (the size of the read-out at that concentration, not a potency): 2.5%
Beside the measured number, compound 3's estimate is 7.5 percentage points above it; measured number inside the range.
By their numbers in this assay, from the lowest: compounds 3 and 1 (each within the scatter of the next); then compound 2.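

In this assay, the change at the amine nitrogen reads differently depending on the sulfonyl compound it is set against: a number 14.8 percentage points lower from compound 2 to compound 3 (beyond the scatter), whereas a number 1.2 percentage points lower from compound 1 to compound 3 (within the scatter). Among these three compounds, then, (4-methoxyphenyl)carbonyl on this nitrogen cannot be told apart from (4-bromophenyl)sulfonyl, and only compound 2, with (4-nitrophenyl)sulfonyl, stands apart from the other two, although each of these steps exchanges the carbonyl or sulfonyl link and the group on the aromatic ring together, so neither step can be credited to the link alone. No supporting measurement is available to explain these differences.

The compounds shown leave open what the link does by itself, a question that (4-nitrophenyl)carbonyl and (4-methoxyphenyl)sulfonyl on the same amine nitrogen would address directly, as each would differ from a compound shown in one feature only. They also leave open how a ring bearing an amine or a carboxylic acid in place of the nitro, bromo or methoxy group would read in this assay.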